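The compounds below may be only part of what the source reports. "The series", "measured", "known", "first", "only" and "open" are said of these compounds alone.

Measured compounds:
compound 1 `Cc1ccccc1-n1cc(-c2ccc(NS(=O)(=O)c3c[nH]c(=O)[nH]c3=O)cc2)nn1`, in a functional assay on A549 cells (Homo sapiens) for antiproliferative activity, read by MTT assay, with a stated time of 24 h (a higher number here means a weaker inhibitor, a lower number a stronger inhibitor), compound 1 gives 3130 nM
compound 2 `O=c1[nH]cc(S(=O)(=O)Nc2ccc(-c3cn(-c4ccccc4F)nn3)cc2)c(=O)[nH]1`, in this assay compound 2 gives 5960 nM
compound 3 `O=c1[nH]cc(S(=O)(=O)Nc2ccc(-c3cn(-c4cccc(F)c4)nn3)cc2)c(=O)[nH]1`, in this assay compound 3 gives 9980 nM

Compound 3 carries the largest of the three numbers, though its gap to compound 2 is small: a 1.7-fold higher number from compound 2 to compound 3 (0.22 log units; within the scatter), whereas a 3.2-fold higher number from compound 1 to compound 3 (0.50 log units; beyond the scatter). Compound 4 `O=c1[nH]cc(S(=O)(=O)Nc2ccc(-c3cn(-c4cccc(Cl)c4)nn3)cc2)c(=O)[nH]1` differs from compound 3 by chloro in place of fluoro on an aromatic carbon. Among the compounds with values here, no measured pair trades fluoro for chloro, so the step can only be judged from the general spread seen so far: a 1.9-fold higher number from compound 1 to compound 2 (0.28 log units; within the scatter), and the two steps above are likewise small. Compound 4 is therefore expected to land close to compound 3 in this assay, with a step of a 1.1-fold lower number from compound 3 to compound 4 (0.04 log units; within the scatter), not beyond the scatter in either direction. The estimate for compound 4 is 9000 nM, within 4000 nM to 20000 nM.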

Compound 4, half-maximal inhibitory concentration: 2310 nM
For compound 4 the middle estimate is 3.9-fold (0.59 log units) above the measured one, and the stated range ends above it.
By their numbers in this assay, from the lowest: compounds 4, 1, 2 and 3 (each within the scatter of the next, the first and the last beyond it).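

In this assay, the halogen at this place on the ring matters on its own: chloro in place of fluoro gives a 4.3-fold lower number from compound 3 to compound 4 (0.64 log units; beyond the scatter) with nothing else changed. The 3-chlorophenyl group also gives a 2.6-fold lower number from compound 2 to compound 4 (0.41 log units; beyond the scatter) against the 2-fluorophenyl group, yet a 1.4-fold lower number from compound 1 to compound 4 (0.13 log units; within the scatter) leaves it level with the 2-methylphenyl group. Nothing measured here accounts for the effect of this exchange. As far as these compounds go, whether bromo, methoxy or an amine at this same place would behave like chloro or like fluoro stays open.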